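Hydrazone aryl swap on the shared core

The compounds below may be only part of what the source reports. "The series", "measured", "known", "first", "only" and "open" are said of these compounds alone.

Measured so far:
compound 1 `Cn1c(=O)c(=O)n(C2CCCC2)c2nc(N/N=C/c3ccco3)ncc21` — in a functional assay on A549 cells (Homo sapiens) for antiproliferative activity, read by MTT assay (on this read-out lower numbers stand for stronger inhibition and higher numbers for weaker inhibition), compound 1 gives only the limit > 100000 nM.
compound 2 `COc1ccc(/C=N/Nc2ncc3c(n2)n(C2CCCC2)c(=O)c(=O)n3C)cc1` — in this assay compound 2 gives only the limit > 100000 nM.

Compound 2 thus stands at the limit of > 100000 nM in this assay, at which 2 of the 2 values shown sit, with no readable number. Within the data shown here, the single measured step, a step that the two limits leave unreadable from compound 1 to compound 2, offers no size. Compound 3 `Cn1c(=O)c(=O)n(C2CCCC2)c2nc(N/N=C/c3cc([N+](=O)[O-])ccc3Cl)ncc21` differs from compound 2 by 2-chloro-5-nitrophenyl in place of 4-methoxyphenyl on a carbon with a double bond to nitrogen. Among the measured compounds shown here, no measured step bears readably on this change, so no direction beyond the scatter can be set; the expected step is a number no higher from compound 2 to compound 3 (the limit leaves the size open). Compound 3 is expected near 100000 nM, within 30000 nM to 300000 nM, most probably again reported as a limit.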

Compound 3, half-maximal inhibitory concentration: 8780 nM
Estimate against measurement, compound 3: 11-fold (1.06 log units) above; the whole stated range lies above it.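

In this assay, the aryl group on the carbon with a double bond to nitrogen proves able to move the read-out, which the earlier pair could not show. Placing 2-chloro-5-nitrophenyl there gives an at least 11-fold lower number from compound 2 to compound 3 (1.05 log units; beyond the scatter), and the comparison with furan-2-yl gives an at least 11-fold lower number from compound 1 to compound 3 (1.05 log units; beyond the scatter). Both steps start from a limit, so each is a minimum size: the limit of > 100000 nM in this assay, at which 2 of the 3 values shown sit.

On these data alone, whether the chlorine or the nitro group carries the step stays open, since the two enter together. Also open, as far as these compounds go, is whether an amine or a carboxylic acid in place of the nitro group would keep it.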